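This account rests on a few compounds, and the source may have more. Where it says the series, first, only, none or still open, it means among the compounds named here.

Compound 1, `Cc1nc(Nc2cccc(Cl)c2)sc1C(=O)/C=C/c1ccccc1`, is one of three close relatives tested in a functional assay on BGC-823 cells (Homo sapiens) for cytotoxicity, read by MTT assay; on this read-out higher numbers stand for weaker inhibition and lower numbers for stronger inhibition. In this assay compound 1 gives > 25000 nM, which is a limit of the assay and not a measured number. Compound 3, `Cc1nc(Nc2cccc(Cl)c2)sc1C(=O)/C=C/c1ccc(Cl)cc1`, differs from compound 1 only by a chloro in place of hydrogen on an aromatic carbon. In this assay compound 3 gives > 25000 nM, again a limit rather than a number. The step that the two limits leave unreadable from compound 1 to compound 3 is therefore not readable as a size, because of the limit of > 25000 nM in this assay, at which 2 of the 3 values shown sit. Compound 2, `Cc1cccc(Nc2nc(C)c(C(=O)/C=C/c3ccccc3Cl)s2)c1`, carries its chloro and methyl groups at other places and is not a single-change relative of either compound; in this assay compound 2 gives 24200 nM, a measured number. Compound 4, `Cc1ccccc1Nc1nc(C)c(C(=O)/C=C/c2ccccc2)s1`, is the compound still to be measured. Its change from compound 1 is 2-methylphenyl in place of 3-chlorophenyl on a nitrogen on an aromatic ring. None of the measured steps touches the group on the aromatic nitrogen, so no measured step bears on this change, and the two limits give no size to reason from. What remains is that every compound shown is weak, so compound 4 is expected to be similarly weak, with the step that the limit leaves unreadable from compound 1 to compound 4 expected to stay within the scatter. The estimate for compound 4 in this assay is 30000 nM, from 10000 nM to 100000 nM, with a real chance that only a limit is reported.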

Compound 4, half-maximal inhibitory concentration: > 25000 nM
Compound 4 ended at the assay's limit; the forecaster's own chance of this, stated with the estimate: 65%; the middle value does not contradict the limit.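

The results for compound 1 and compound 4 are both limits of this assay and not measured numbers, so the step between them cannot be read, because neither compound has a number to compare: the limit of > 25000 nM in this assay, at which 3 of the 4 values shown sit.

The compounds shown leave open how far 3-chlorophenyl and 2-methylphenyl on the nitrogen really differ in this assay, and whether any change to the shared core gives clearly stronger inhibition.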